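The source may hold more compounds than are shown below. What is called first, only, known or untested is meant among the compounds shown, and "the series" means these compounds.

Measured in a physicochemical assay for solubility, at pH 7.4; on this read-out higher numbers stand for higher solubility and lower numbers for lower solubility:
Compound 1 `CNC1(C)CN(c2cc3c(cc2F)c(=O)c(C(=O)O)cn3C2CC2)C1` gives 0.7 ug/mL
Compound 2 `C[C@H]1[C@@H](N)CN1c1cc2c(cc1F)c(=O)c(C(=O)O)cn2C1CC1` gives 6.1 ug/mL
Compound 3 `C[C@H]1N(c2cc3c(cc2F)c(=O)c(C(=O)O)cn3C2CC2)C[C@]1(C)N` awaits measurement

Compound 2 at 6.1 ug/mL stands highest of the two measured compounds. Compound 3 differs from it thus: a group of 7 heavy atoms (5 carbon, 2 nitrogen; one four-membered non-aromatic ring with 1 hetero atom) in place of a group of 6 heavy atoms (4 carbon, 2 nitrogen; one four-membered non-aromatic ring with 1 hetero atom), on an aromatic carbon. Going by the values given here, one measured step bears on this, an 8.7-fold higher number from compound 1 to compound 2 (0.94 log units; beyond the scatter), where a group of 6 heavy atoms replaced a group of 7 heavy atoms. Compound 3 goes the opposite way, so a lower number of similar or smaller size is expected in this assay, though one step is thin support. The expected change is a 3.1-fold lower number from compound 2 to compound 3 (0.48 log units; beyond the scatter) and no more. For compound 3 the estimate is 2 ug/mL within an expected range of 0.6 ug/mL to 7 ug/mL on this evidence.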

Compound 3, solubility: 1.3 ug/mL
Estimate against measurement, compound 3: 1.5-fold (0.19 log units) above; the measured number falls inside the stated range.
By their numbers in this assay, from the lowest: compounds 1 and 3 (each within the scatter of the next); then compound 2.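

In this assay, this position on the aromatic carbon ortho to a fluoro group responds to a small change in the four-membered ring group: the group of 7 heavy atoms in place of the group of 6 heavy atoms gives a 4.7-fold lower number from compound 2 to compound 3 (0.67 log units; beyond the scatter) here. The two groups of 7 heavy atoms do not separate, with a 1.9-fold higher number from compound 1 to compound 3 (0.27 log units; within the scatter) as their step, so compound 2 alone stands apart from both. Nothing measured here accounts for these differences. On these data alone, what a hydroxyl group in place of the amine, or an ethyl group on the four-membered ring, would give remains open.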